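This account rests on a few compounds, and the source may have more. Where it says the series, first, only, none or still open, it means among the compounds named here.

Three compounds share one core, and two of them have a number in an assay on CHO cells for agonist activity at Free fatty acid receptor 1 (Homo sapiens), read by luminescence, with a stated time of 20 s, in the presence of a further agent that is not named here; a higher number here means that more compound is needed for the effect, a lower number that less compound is needed. Compound 1 `CCc1ccccc1-c1cccc(COc2ccc([C@H](CC(=O)O)c3nccn3C)cc2)c1` gives 65000 nM in this assay. Compound 2 `COc1ccccc1-c1cccc(COc2ccc([C@H](CC(=O)O)c3nccn3C)cc2)c1` stands in this assay as "not determined" (no result reported), so no number exists for it. Within the data shown here, compound 3 `Cn1ccnc1[C@@H](CC(=O)O)c1ccc(OCc2cccc(-c3ccc(Cl)cc3Cl)c2)cc1` gives 30000 nM, the lower of the two numbers; the one step leading to it, a 2.2-fold lower number from compound 1 to compound 3 (0.34 log units; beyond the scatter), is modest but beyond the scatter. Compound 4 `Cc1ccc(F)cc1-c1cccc(COc2ccc([C@H](CC(=O)O)c3nccn3C)cc2)c1` is not yet measured. It differs from compound 3 in one place: 5-fluoro-2-methylphenyl in place of 2,4-dichlorophenyl on an aromatic carbon. Among the measured compounds shown here, the only measured step bearing on this change is a 2.2-fold lower number from compound 1 to compound 3 (0.34 log units; beyond the scatter), which also exchanged one ring for another on an aromatic carbon. The incoming ring of compound 4 carries a methyl group, closer in kind to the ethyl group of compound 1 than to the two chlorines of compound 3, so the number is expected to move part of the way back toward compound 1. The step of a 1.5-fold higher number from compound 3 to compound 4 (0.18 log units; within the scatter) is thus expected to be small and upward. For compound 4 the estimate in this assay is 45000 nM, within a range from 20000 nM to 120000 nM.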

Compound 4, half-maximal effective concentration: 42000 nM
Compound 4: the middle estimate sits 1.1-fold (0.03 log units) above what was measured, and the stated range covers the measured number.
By their numbers in this assay, from the lowest: compounds 3, 4 and 1 (each within the scatter of the next, the first and the last beyond it).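

In this assay, putting 5-fluoro-2-methylphenyl on this aromatic carbon in place of 2,4-dichlorophenyl gives a 1.4-fold higher number from compound 3 to compound 4 (0.15 log units; within the scatter), and putting it in place of 2-ethylphenyl gives a 1.5-fold lower number from compound 1 to compound 4 (0.19 log units; within the scatter), so compound 4 cannot be told apart from either compound. Only compound 1 and compound 3 remain separated beyond the scatter, which means that this new pattern of methyl and fluorine on the ring adds no clear distinction among the three rings with numbers. Nothing shown here explains why these rings give such similar results.

From the compounds shown here alone, all three carry only alkyl or halogen groups, so the effect of an amine or a hydroxyl group on this ring remains open. Also open, going by these compounds, is whether a longer chain linking this ring to the shared core would change the number.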